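The source may hold more compounds than are shown below. What is called first, only, known or untested is meant among the compounds shown, and "the series" means these compounds.

Compound 1 `C=CC(=O)NCc1coc(-c2c(N)ncnc2Nc2ccc(OCc3cccc(F)c3)c(Cl)c2)n1`: in an in vitro ADME assay on microsomes from liver (Homo sapiens) for metabolic stability, tested at 5 uM (on this read-out lower numbers stand for a shorter-lived compound and higher numbers for a longer-lived compound), compound 1 gives 0.75 h.
Compound 2 `C=CC(=O)NCc1coc(-c2c(N)ncnc2Nc2ccc(Oc3ccccc3)c(Cl)c2)n1`: in this assay compound 2 gives > 1.66 h, which is a limit of the assay and not a number.
Compound 3 `C=CC(=O)NCc1coc(-c2c(N)ncnc2Nc2ccc(Oc3ccccn3)c(Cl)c2)n1`: in this assay compound 3 gives 0.65 h.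

Among the two numbers that are not limits, compound 1 stands highest, though its nearest neighbour, compound 3, lies within the scatter of it. Compound 4 `C=CC(=O)NCc1coc(-c2c(N)ncnc2Nc2ccc(Oc3cccnc3)c(Cl)c2)n1` has not yet been measured in this assay. The change from compound 1 to compound 4 is pyridin-3-yl in place of 3-fluorobenzyl on an oxygen on an aromatic ring.

Going by the values given here, two measured steps bear on this. The exchange of 3-fluorobenzyl for a six-membered aromatic ring of carbon only gave an at least 2.2-fold higher number from compound 1 to compound 2 (0.34 log units; beyond the scatter), where the number for compound 2 is a limit (the limit of > 1.66 h in this assay, at which 1 of the 3 values shown sits). The exchange of 3-fluorobenzyl for pyridin-2-yl gave a 1.2-fold lower number from compound 1 to compound 3 (0.06 log units; within the scatter). The pyridin-3-yl of compound 4 shares a ring nitrogen with compound 3 and a directly attached aromatic ring with compound 2, so the expected step, a 1.1-fold higher number from compound 1 to compound 4 (0.05 log units; within the scatter), is set between those two outcomes and not clearly beyond the scatter in either direction. Compound 4 is therefore estimated at 0.85 h, with a range from 0.4 h to 1.66 h.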

Compound 4, half-life: 0.25 h
For compound 4 the middle estimate is 3.4-fold (0.53 log units) above the measured one, outside the stated range (below it).
By their numbers in this assay, from the lowest: compound 4; then compounds 3 and 1 (each within the scatter of the next). At a limit, above all of these: compound 2.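

The earlier compounds shown here left open whether a ring nitrogen on this oxygen mattered only by being present, and the result shows that its placement counts: the half-life gives a 2.6-fold lower number from compound 3 to compound 4 (0.41 log units; beyond the scatter), so pyridin-3-yl and pyridin-2-yl are not interchangeable here. A directly attached aromatic ring also does not by itself bring a longer half-life, since replacing 3-fluorobenzyl with pyridin-3-yl gives a 3.0-fold lower number from compound 1 to compound 4 (0.48 log units; beyond the scatter), the opposite direction to the step seen with phenyl. Set against the carbon-only ring, the ring nitrogen of pyridin-3-yl gives an at least 6.6-fold lower number from compound 2 to compound 4 (0.82 log units; beyond the scatter), and the value of compound 2 in that step is a limit and not a number: the limit of > 1.66 h in this assay, at which 1 of the 4 values shown sits.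

The compounds shown do not tell whether pyridin-4-yl on the same oxygen would fall nearer to compound 3 or to compound 4. Nor do they tell whether pyridin-3-ylmethyl, which would carry the same ring on the chain of the benzyl group, would keep the half-life of compound 1 or follow compound 4.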